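This account rests on a few compounds, and the source may have more. Where it says the series, first, only, none or still open, it means among the compounds named here.

Of the compounds shown here, two in this set have been read in an ADME assay on MT4 cells (Homo sapiens) for cytotoxicity, read by MTT assay, with a stated time of 96 h; on this read-out higher numbers stand for lower toxicity in this test and lower numbers for higher toxicity in this test. Compound 1 `Cc1ccc(-c2nn(-c3ccccc3)cc2CNc2ccc(Br)cc2)cc1` carries a 4-methylphenyl on its core, and in this assay compound 1 reaches only a limit, > 100000 nM. Compound 2 `FC(F)(F)c1ccc(NCc2cn(-c3ccccc3)nc2-c2ccccc2)cc1` carries a phenyl on the same core, and in this assay compound 2 likewise gives only a limit, > 100000 nM. Compound 2 thus stands at the limit of > 100000 nM in this assay, at which 2 of the 2 values shown sit, and no numeric value separates it from compound 1. Compound 3 `Cc1ccc(-c2nn(-c3ccccc3)cc2CNc2ccc(C(F)(F)F)cc2)cc1` differs from compound 2 by methyl in place of hydrogen on an aromatic carbon. Within the data shown here, with both measured values sitting at the limit, no measured step between compounds is available to lean on, and the expected step in this assay is none beyond the scatter: a number no higher from compound 2 to compound 3 (the limit leaves the size open). Compound 3 is therefore expected to show 100000 nM, most likely reported once more only as a limit, within a range from 50000 nM to 300000 nM.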

Compound 3, half-maximal cytotoxic concentration: > 100000 nM
Compound 3 was reported as a limit; the forecaster's own chance of this, stated with the estimate: 80%; the middle value sits exactly at the limit.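

No new step can be read from compound 1 or compound 2 to compound 3, since all three stand at the same limit: the limit of > 100000 nM in this assay, at which 3 of the 3 values shown sit.
The compounds shown leave open how the three truly compare, and whether methyl in place of hydrogen or trifluoromethyl in place of bromo changes the read-out at all.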